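The source may hold more compounds than are shown below. What is called first, only, known or untested is meant among the compounds shown, and "the series" means these compounds.

Of the compounds shown here, two have so far been measured in an assay on cells for inhibition of Rho-associated protein kinase 2 (Homo sapiens); on this read-out lower numbers stand for stronger inhibition and higher numbers for weaker inhibition. Compound 1 `O=C(Nc1cc(F)c(-c2cn[nH]c2)c(F)c1)C1COc2ccccc2C1` gives 15 nM in this assay, while compound 2 `Cc1ccc2c(c1)CC(C(=O)Nc1ccc(-c3cn[nH]c3)cc1)CO2` gives 4000 nM, the higher of the two numbers by a margin well beyond the scatter. From compound 2 the study moves to compound 3 `O=C(O)c1ccc2c(c1)CC(C(=O)Nc1ccc(-c3cn[nH]c3)cc1)CO2`, which differs by carboxy in place of methyl on an aromatic carbon. Among the measured compounds shown here, no measured pair shows the effect of such a change, so the expected step of a 1.3-fold lower number from compound 2 to compound 3 (0.12 log units; within the scatter) is judged small, with no clear direction beyond the scatter. Compound 3 is therefore estimated at 3000 nM in this assay, with a range from 600 nM to 15000 nM.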

Compound 3, half-maximal inhibitory concentration: 751 nM
For compound 3 the middle estimate is 4.0-fold (0.60 log units) above the measured one, and the stated range covers the measured number.
By their numbers in this assay, from the lowest: compound 1; then compound 3; then compound 2.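

Carboxy in place of methyl on this aromatic carbon brings a 5.3-fold lower number from compound 2 to compound 3 (0.73 log units; beyond the scatter) in this assay, the first sign that the number responds to what this position carries. The step is modest, and no measurement at hand says why the number falls. The compounds shown leave open whether the effect belongs to carboxy itself or would also appear with a primary amide, a hydroxymethyl or an amine on the same carbon. On these data alone, whether carboxy would act the same way on the core of compound 1 also remains open.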